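The compounds below may be only part of what the source reports. "The series", "measured", "known", "first", "only" and "open" are said of these compounds alone.

Compound 2, `COc1cc(/C=C/C(=O)c2cccc(-n3cc(-c4ccccc4)[nH]c3=O)c2)ccc1O`: 2960 nM
Compound 1, `COc1cc(/C=C/C(=O)c2cccc(-n3cc(-c4ccc(Cl)cc4)[nH]c3=O)c2)cc(OC)c1OC`: 16100 nM

In a functional assay on SNB-19 cells (Homo sapiens) for inhibition (on this read-out higher numbers stand for weaker inhibition of growth and lower numbers for stronger inhibition of growth), compound 2 has the lower of the two numbers recorded. Compound 1 differs from it in more than one place, and in this assay compound 1 gives 16100 nM, a number beyond the usual scatter from that of compound 2, so the two values can only be set side by side. The unmeasured compound 3, `O=C(/C=C/c1cccc(O)c1)c1cccc(-n2cc(-c3ccccc3)[nH]c2=O)c1`, departs from compound 2 in a single place: 3-hydroxyphenyl in place of 4-hydroxy-3-methoxyphenyl on a double-bonded chain carbon bound to a double-bonded chain carbon. Among the compounds with values here, no pair of measured compounds differing in one place is available to gauge such a change. Compound 3 is therefore expected to stay close to compound 2, with a step from compound 2 to compound 3 of a 1.4-fold higher number from compound 2 to compound 3 (0.13 log units; within the scatter), expected to lie within the scatter or slightly toward weaker growth inhibition. Compound 3 is estimated at 4000 nM, with a range from 1500 nM to 12000 nM.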

Compound 3, concentration for 50% growth inhibition: 10900 nM
The estimate for compound 3 lay 2.7-fold (0.44 log units) below the measured number; measured number inside the range.
By their numbers in this assay, from the lowest: compound 2; then compounds 3 and 1 (each within the scatter of the next).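

In this assay, within the data shown here, putting 3-hydroxyphenyl in place of 4-hydroxy-3-methoxyphenyl on a double-bonded chain carbon bound to a double-bonded chain carbon gives the first single-place comparison in this set (a 3.7-fold higher number from compound 2 to compound 3 (0.57 log units; beyond the scatter)). It shows that this position is not indifferent to the group it carries, since the entering group weakens growth inhibition beyond the scatter while the shared core stays the same. The change alters the hydroxy placement and removes the methoxy in one step, and no measurement offered here explains the loss or assigns it to either feature alone.

The compounds shown leave open how a 4-hydroxyphenyl or a 3-methoxyphenyl group would compare at this position, which would separate the two features. They also leave open how an amine or a carboxylic acid on this ring would fare.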